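Cyclopropyl amides: para halogen swap on the aryl ring

This account rests on a few compounds, and the source may have more. Where it says the series, first, only, none or still open, it means among the compounds named here.

The series is followed in a toxicity assay on the whole organism (strain Icem-CET (SPF Caw)) for cytotoxicity, with Mus musculus as the target; on this read-out higher numbers stand for an effect only at larger amounts of compound and lower numbers for an effect already at smaller amounts. For the measured compounds named here, compound 2 `C/C(C(=O)NC1CC1)=C(\C)c1ccccc1` gives 300 mg/kg and compound 3 `C/C(C(=O)NC1CC1)=C(\C)c1ccc(Cl)cc1` gives 600 mg/kg; the step of a 2.0-fold higher number from compound 2 to compound 3 (0.30 log units; within the scatter) is the only single-point change so far, and it stays within the scatter. Compound 1 `C/C(C(=O)NC1CC1)=C(/C)c1ccc(F)cc1` carries the fluoro at the same aromatic carbon as compound 4 but with the other arrangement of the substituents about the double bond. In this assay compound 1 gives 70 mg/kg. Compound 3 thus stands highest of the three numbers, with compound 2 within the scatter of it and compound 1 well beyond.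

Compound 4 `C/C(C(=O)NC1CC1)=C(\C)c1ccc(F)cc1` is not yet measured. It differs from compound 3 by fluoro in place of chloro on an aromatic carbon. Going by the values given here, no measured step exchanges one halogen for another; the step from compound 2 to compound 3 shows only that adding chloro to the bare ring changes nothing beyond the scatter, which argues for a small step here as well. Compound 1 gives a much lower number, but its double bond geometry differs, so it is not a direct guide. The step of a 2.0-fold lower number from compound 3 to compound 4 (0.30 log units; within the scatter) is therefore expected to stay within the scatter, if anything downward. Compound 4 is estimated at 300 mg/kg, within a range of 120 mg/kg to 750 mg/kg.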

Compound 4, dose for half-maximal effect: 600 mg/kg
Compound 4: the middle estimate sits 2.0-fold (0.30 log units) below what was measured, and the stated range covers the measured number.
By their numbers in this assay, from the lowest: compound 1; then compounds 2, 3 and 4 (each within the scatter of the next).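

For the compounds shown here, at the aromatic carbon para to a large group, the first direct exchange of one halogen for another gives no change at the digits printed from compound 3 to compound 4 (within the scatter) in this assay, so fluoro and chloro cannot be told apart at this position on this read-out. Set against the bare ring, fluoro gives a 2.0-fold higher number from compound 2 to compound 4 (0.30 log units; within the scatter), which matches the picture from chloro: in this double bond arrangement, neither halogen separates from hydrogen beyond the scatter. The pair of compounds with opposite arrangements about the double bond gives an 8.6-fold higher number from compound 1 to compound 4 (0.93 log units; beyond the scatter), the only step in the series beyond the scatter, and this gap can be assigned to the arrangement about the double bond rather than to the ring substituent: the fact that compounds 1 and 4 differ only in the configuration as drawn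

Going by these compounds alone, still open is whether the double bond arrangement carries the same weight with chloro or hydrogen on the ring, as the only matched pair for this comparison carries fluoro. Also open, going by these compounds, is how this assay responds to a non-halogen group at this aromatic carbon, such as an amine or a carboxylic acid, or to a longer chain in place of the cyclopropyl on the amide.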